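Carbonyl substituent step from compound 2 to compound 3

The source may hold more compounds than are shown below. What is called first, only, known or untested is meant among the compounds shown, and "the series" means these compounds.

Measured so far in a functional assay on A549 cells (Homo sapiens) for inhibition, read by MTT assay, with a stated time of 96 h; on this read-out lower numbers stand for stronger inhibition of growth and higher numbers for weaker inhibition of growth:
- compound 1 `O=C(OCc1ccccc1)SCCCCCCNC(=O)c1cc(-c2ccncc2)n[nH]1` gives 13400 nM
- compound 2 `CC(C)C(=O)SCCCCCCNC(=O)c1cc(-c2ccncc2)n[nH]1` gives 16800 nM

In this assay, among the compounds with values here, compound 2 gives 16800 nM and lies within the scatter of compound 1, the only other measured member of the series. Compound 3 `C=CCOC(=O)SCCCCCCNC(=O)c1cc(-c2ccncc2)n[nH]1` has not yet been measured. Its structure carries allyloxy in place of isopropyl on a carbonyl carbon. Within the data shown here, one measured step bears on this change, at the same carbonyl carbon, where isopropyl replaced benzyloxy. That step, a 1.3-fold higher number from compound 1 to compound 2 (0.10 log units; within the scatter), is small. Allyloxy itself has not been tested, and a single step is thin evidence. Among the measured compounds shown here, still, the only swap measured at this carbonyl carbon moved the number by no more than the scatter, so no larger move is expected here. The expected step is a 1.2-fold lower number from compound 2 to compound 3 (0.06 log units; within the scatter), which would leave compound 3 level with the two measured compounds. For compound 3 the estimate is 14500 nM, with an expected range from 7000 nM to 29000 nM.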

Compound 3, concentration for 50% growth inhibition: 15200 nM
Compound 3: the middle estimate sits 1.0-fold (0.02 log units) below what was measured; low and high end bracket the measured number.
By their numbers in this assay, from the lowest: compounds 1, 3 and 2 (each within the scatter of the next).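

In this assay, the swap on the carbonyl carbon whose other neighbour is sulfur (a 1.1-fold lower number from compound 2 to compound 3 (0.04 log units; within the scatter)) shows that allyloxy, with its oxygen, double bond and hydrogen-bond acceptor, can replace isopropyl without a difference beyond the scatter. The second new comparison (a 1.1-fold higher number from compound 1 to compound 3 (0.05 log units; within the scatter)) adds that vinyl in place of phenyl, which removes the ring from the oxygen-bound substituent, also leaves the number within the scatter. Isopropyl, benzyloxy and allyloxy therefore cannot be told apart here, a flat picture now covering three substituents rather than one pair, and no supporting measurement is available to explain it.

Still open, going by these compounds, is whether a substituent of a different kind on this carbonyl carbon, such as an amine or a carboxylic acid, would separate from these three compounds in this assay. Also open, on these data alone, is how much the sulfur link and the chain contribute, for example whether an oxygen in place of the sulfur or a longer chain would move the number beyond the scatter while the rest of the shared core stays unchanged.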